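This account rests on a few compounds, and the source may have more. Where it says the series, first, only, none or still open, it means among the compounds named here.

Measured so far:
compound 1, `CN(C)CC[C@H](CSc1ccccc1)Nc1ccc(S(=O)(=O)NC(=O)c2ccc(N3CCN(C(=O)Nc4ccccc4)CC3)cc2)cc1[N+](=O)[O-]` — > 50000 nM in a functional assay (FL5.12 cells, Mus musculus) with Apoptosis regulator Bcl-2 (Homo sapiens) as the target; on this read-out higher numbers stand for an effect only at larger amounts of compound and lower numbers for an effect already at smaller amounts
compound 2, `CN(C)CC[C@H](CSc1ccccc1)Nc1ccc(S(=O)(=O)NC(=O)c2ccc(N3CCN(Cc4ccccc4)CC3)cc2)cc1[N+](=O)[O-]` — 1700 nM in this assay

Among the compounds with values here, compound 2 stands at the only number in the set; its value in this assay is 1700 nM. The value of compound 1 is a limit of the assay, (the limit of > 50000 nM in this assay, at which 1 of the 2 values shown sits). Within the data shown here, the single measured step, an at least 29-fold lower number from compound 1 to compound 2 (1.46 log units; beyond the scatter), concerns the group on the ring amine nitrogen. Compound 3, `COc1ccccc1CN1CCN(c2ccc(C(=O)NS(=O)(=O)c3ccc(N[C@H](CCN(C)C)CSc4ccccc4)c([N+](=O)[O-])c3)cc2)CC1`, differs from compound 2 by methoxy in place of hydrogen on an aromatic carbon of the benzyl group. Among the measured compounds shown here, no measured step touches that ring; the only step bears on it indirectly. A step of no change at the digits printed from compound 2 to compound 3 (within the scatter) is therefore expected, within the scatter. Compound 3 is expected to give 1700 nM, range 600 nM to 5000 nM.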

Compound 3, half-maximal effective concentration: 950 nM
Estimate against measurement, compound 3: 1.8-fold (0.25 log units) above; low and high end bracket the measured number.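

In this assay, the benzyl ring accepts methoxy on an aromatic carbon ortho to a large group, with a 1.8-fold lower number from compound 2 to compound 3 (0.25 log units; within the scatter). The large gap to phenylcarbamoyl also holds for the substituted benzyl, with an at least 52-fold lower number from compound 1 to compound 3 (1.72 log units; beyond the scatter). The value of compound 1 is a limit and not a number: the limit of > 50000 nM in this assay, at which 1 of the 3 values shown sits.

A single substituent at a single place on this ring cannot show how far this tolerance extends. Going by these compounds, what a carboxylic acid or an amine on this ring would give stays open, as does methoxy on another carbon of it.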